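Swapping one side group for tert-butyl

The compounds below may be only part of what the source reports. "The series", "measured", "known", "first", "only" and "open" are said of these compounds alone.

Measured in a functional assay on CFPAC-1 cells (Homo sapiens) for antiproliferative activity, read by MTT assay, with a stated time of 72 h; a higher number here means a weaker inhibitor, a lower number a stronger inhibitor:
Compound 1 `CCCCCc1ccc(-c2cn(C[C@H](O)[C@H]3OC(=O)C(OCc4ccccc4)=C3OCc3ccccc3)nn2)cc1`: 9890 nM
Compound 2 `COc1ccccc1-c1cn(C[C@H](O)[C@H]2OC(=O)C(OCc3ccccc3)=C2OCc2ccccc2)nn1`: > 100000 nM (a limit)
Compound 3 `O=C1O[C@H]([C@@H](O)Cn2cc(CNS(=O)(=O)c3ccc(F)cc3)nn2)C(OCc2ccccc2)=C1OCc1ccccc1`: 34700 nM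

Compound 1 gives 9890 nM, and compound 3 gives 34700 nM, the higher of the two actual numbers. Compound 2 has > 100000 nM, which is a limit and not a number.

Compound 4 `CC(C)(C)c1cn(C[C@H](O)[C@H]2OC(=O)C(OCc3ccccc3)=C2OCc2ccccc2)nn1` has tert-butyl in place of (((4-fluorophenyl)sulfonyl)amino)methyl on an aromatic carbon. Three measured swaps at this same carbon bear on it: a 3.5-fold higher number from compound 1 to compound 3 (0.55 log units; beyond the scatter), an at least 2.8-fold lower number from compound 2 to compound 3 (0.45 log units; beyond the scatter) and an at least 10-fold higher number from compound 1 to compound 2 (1.00 log units; beyond the scatter). All lie beyond the scatter, yet none brings in tert-butyl. Only a slight rise in this assay, within the scatter, is therefore expected, an estimated 1.6-fold higher number from compound 3 to compound 4 (0.20 log units; within the scatter). For compound 4 the estimated value is 55000 nM, with an expected range of 15000 nM to 100000 nM.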

Compound 4, half-maximal inhibitory concentration: 54900 nM
Beside the measured number, compound 4's estimate is 1.0-fold (0.00 log units) above it, and the stated range covers the measured number.
By their numbers in this assay, from the lowest: compound 1; then compounds 3 and 4 (each within the scatter of the next). At a limit, above all of these: compound 2.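

In this assay, tert-butyl, with no ring and no hydrogen-bond donors or acceptors, takes the place of the larger (((4-fluorophenyl)sulfonyl)amino)methyl, with a 1.6-fold higher number from compound 3 to compound 4 (0.20 log units; within the scatter). The 4-pentylphenyl group still stands apart, with a 5.6-fold higher number from compound 1 to compound 4 (0.74 log units; beyond the scatter). Compound 2 gives only a limit and not a number: the limit of > 100000 nM in this assay, at which 1 of the 4 values shown sits. Tert-butyl in place of 2-methoxyphenyl gives an at least 1.8-fold lower number from compound 2 to compound 4 (0.26 log units; that floor lies within the scatter).

Whether the ring or the pentyl chain of compound 1 accounts for its lower number stays open. So does the effect of a plain pentyl chain or an amine on this aromatic carbon.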